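4-(Dimethylamino)phenyl to 1H-indol-3-yl at the assay limit

The source may report more compounds than this note shows. Statements on the series, on what has been measured and on what is new or still open speak of the compounds shown alone.

In a functional assay on MCF7 cells (Homo sapiens) for antiproliferative activity (a higher number here means a weaker inhibitor, a lower number a stronger inhibitor), compound 1 (`COc1ccc(-c2cn(C3Cc4ccc(O[C@@H]5OC(C)(C)[C@H](OC)[C@@H](O)[C@H]5O)c(C)c4OC3=O)nn2)cc1`) gives > 100000 nM as a limit of the assay, not a number. Compound 2 (`CO[C@@H]1[C@@H](O)[C@@H](O)[C@H](Oc2ccc3c(c2C)OC(=O)C(n2cc(-c4ccc(N(C)C)cc4)nn2)C3)OC1(C)C`) likewise gives > 100000 nM as a limit, not a number. Among the compounds with values here, the position of the series so far is the limit of > 100000 nM in this assay, at which 2 of the 2 values shown sit, and neither compound has a readable value. Within the data shown here, the only measured step is a step that the two limits leave unreadable from compound 1 to compound 2 with dimethylamino in place of methoxy on an aromatic carbon, and it offers no size to carry forward.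

Compound 3 (`CO[C@@H]1[C@@H](O)[C@@H](O)[C@H](Oc2ccc3c(c2C)OC(=O)C(n2cc(-c4c[nH]c5ccccc45)nn2)C3)OC1(C)C`) carries 1H-indol-3-yl in place of 4-(dimethylamino)phenyl on an aromatic carbon of the five-membered aromatic ring with 3 nitrogen (1H-indol-3-yl in place of 4-(dimethylamino)phenyl on an aromatic carbon). This is a different group from those in the two measured compounds, so the data give no firm direction. The likeliest result in this assay is another limit or a weak value close to it. The expected change is an at least 1.4-fold lower number from compound 2 to compound 3 (0.15 log units; that floor lies within the scatter) and it may prove unreadable. For compound 3 the expected value is 70000 nM with 15000 nM to 150000 nM as the estimated range.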

Compound 3, half-maximal inhibitory concentration: 18300 nM
For compound 3 the middle estimate is 3.8-fold (0.58 log units) above the measured one, and the stated range covers the measured number.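

Placing 1H-indol-3-yl on the aromatic carbon of the five-membered aromatic ring with 3 nitrogen gives the first readable value at this position in this assay, with an at least 5.4-fold lower number from compound 2 to compound 3 (0.73 log units; beyond the scatter) and, against 4-methoxyphenyl, an at least 5.4-fold lower number from compound 1 to compound 3 (0.73 log units; beyond the scatter). Each step starts from a limit, so both sizes are floors, and the position is shown to respond to the group it carries, which the first two compounds could not show. Activity remains weak and compound 3 is the only readable point, with the rest of the series still at the assay ceiling: the limit of > 100000 nM in this assay, at which 2 of the 3 values shown sit.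

The compounds shown do not tell whether the change depends on the hydrogen-bond donor of 1H-indol-3-yl or on its five-membered aromatic ring with 1 hetero atom, and the step between compound 1 and compound 2 cannot be read. Values for 1-methyl-1H-indol-3-yl, which keeps both rings but lacks the ring hydrogen on nitrogen, and for naphthyl, which has two rings of carbon only, would separate these two readings.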